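A few compounds are considered here, and "the series" means these few. Any claim that something is new, unique, unknown or untested is made for them only; others in the source may bear on it.

Compound 1 `O=S(=O)(c1cccc(F)c1)c1cnc2c(F)cccc2c1-c1cccc(Cl)c1`: 0.56 mL/min
Compound 2 `N#Cc1cccc(S(=O)(=O)c2cnc3c(F)cccc3c2-c2cccc(Cl)c2)c1`: 1.11 mL/min

In an ADME assay on microsomes from liver (Homo sapiens) for metabolic stability, tested at 2.5 uM (on this read-out lower numbers stand for slow clearance and higher numbers for fast clearance), compound 1 gives 0.56 mL/min, the lowest of the two numbers shown. Going by the values given here, compound 2 gives 1.11 mL/min; the one measured step, a 2.0-fold higher number from compound 1 to compound 2 (0.30 log units; within the scatter), stays within the scatter. Compound 3 `O=S(=O)(c1cccc(F)c1)c1cnc2c(F)cccc2c1-c1cccc(F)c1` differs from compound 1 by fluoro in place of chloro on an aromatic carbon. Among the compounds with values here, no measured step covers that change, and the only step known concerns another position and was small, so the step of a 1.1-fold lower number from compound 1 to compound 3 (0.05 log units; within the scatter) is expected to stay within the scatter. Compound 3 is estimated at 0.5 mL/min, within a range of 0.25 mL/min to 1 mL/min in this assay.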

Compound 3, intrinsic clearance in a liver preparation (reported as CLH), per the amount of preparation that the assay uses: 1.14 mL/min
Estimate against measurement, compound 3: 2.3-fold (0.36 log units) below, outside the stated range (above it).
By their numbers in this assay, from the lowest: compounds 1, 2 and 3 (each within the scatter of the next, the first and the last beyond it).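

In this assay, going by these compounds alone, replacing 3-chlorophenyl with 3-fluorophenyl gives a 2.0-fold higher number from compound 1 to compound 3 (0.31 log units; beyond the scatter), the first step here to pass the scatter, though only modestly. So even an exchange of one halogen for another at this place, with no hydrogen-bond donor or acceptor entering or leaving, can shift the clearance number. Nothing measured here explains the shift.

On these data alone, it remains open whether an amine or a methoxy group at this place would shift the number further. Also open, as far as these compounds go, is whether the same exchange would have a similar effect in compound 2, which carries the nitrile.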